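Swapping Trifluoromethyl for 4-Hydroxyphenyl on Compound 1

This account rests on a few compounds, and the source may have more. Where it says the series, first, only, none or still open, it means among the compounds named here.

For the measured compounds named here, in a physicochemical assay for solubility, read by HPLC, in phosphate buffer, with a stated time of 24 h, at pH 7.4 (on this read-out higher numbers stand for higher solubility and lower numbers for lower solubility), compound 1 (`COc1ccc(Cn2nnc(O)c2C(=O)Nc2cccc(C(F)(F)F)c2)cc1`) gives 21200 nM, the only true number so far. Compound 2 (`COc1ccc(Cn2nnc(O)c2C(=O)Nc2ccc(-c3ccccc3)cc2)cc1`) gives < 1000 nM, which is a limit of the assay and not a number. Compound 3 (`COc1ccc(Cn2nnc(O)c2C(=O)Nc2cccc(-c3ccc(O)cc3)c2)cc1`) has 4-hydroxyphenyl in place of trifluoromethyl on an aromatic carbon, meta to a large group (4-hydroxyphenyl in place of trifluoromethyl on an aromatic carbon). Going by the values given here, no measured step can guide this change, so the expectation leans only on the limit that compound 2 shows at < 1000 nM. A clear fall in this assay is expected, estimated as an 8.5-fold lower number from compound 1 to compound 3 (0.93 log units; beyond the scatter). The estimated value for compound 3 is 2500 nM, with an expected range of 700 nM to 9000 nM.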

Compound 3, solubility: 2050 nM
Estimate against measurement, compound 3: 1.2-fold (0.09 log units) above; measured number inside the range.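

For the compounds shown here, putting 4-hydroxyphenyl in place of trifluoromethyl on this aromatic carbon gives a 10-fold lower number from compound 1 to compound 3 (1.01 log units; beyond the scatter) in this assay, the first step that can be read between two true numbers. The change is large, yet compound 3 still gives a true number, so the size of the fall can be stated. Compound 2 remains a limit of the assay and not a number: the limit of < 1000 nM in this assay, at which 1 of the 3 values shown sits.

The compounds shown leave open whether this fall goes with the added ring or with its hydroxyl group. Going by these compounds, how an amine or a carboxylic acid on this same carbon would read also stays open.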